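This account rests on a few compounds, and the source may have more. Where it says the series, first, only, none or still open, it means among the compounds named here.

Measured compounds in a functional assay on Ehrlich cells (Mus musculus) for cytotoxicity, read by trypan blue exclusion, with a stated time of 2 h, tested at 100 ug/mL; a lower number here means a weaker effect, a higher number a stronger effect of the compound at the concentration tested:

- compound 1 `N#CC1=C(N)N(c2ccc(S(N)(=O)=O)cc2)C2=C(C(=O)CCC2)C1c1ccc(Cl)cc1Cl` gives 95%
- compound 2 `C=CCNC(=S)NC1=C(C#N)C(c2ccc(Cl)cc2Cl)C2=C(CCCC2=O)N1c1ccc(S(N)(=O)=O)cc1` gives 40%
- compound 3 `N#CC1=C(NC(=S)Nc2ccccc2)N(c2ccc(S(N)(=O)=O)cc2)C2=C(C(=O)CCC2)C1c1ccc(Cl)cc1Cl` gives 95%

Compound 3 stands level with compound 1, and the two together hold the highest numbers of the three in this assay. Compound 2 lies furthest away: a number 55 percentage points higher from compound 2 to compound 3 (beyond the scatter), a large step, while no change at the digits printed from compound 1 to compound 3 (within the scatter). Seen from compound 1, a number 55 percentage points lower from compound 1 to compound 2 (beyond the scatter).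

Compound 4 `N#CC1=C(NC(=S)Nc2ccc(Cl)cc2)N(c2ccc(S(N)(=O)=O)cc2)C2=C(C(=O)CCC2)C1c1ccc(Cl)cc1Cl` differs from compound 3 in one place: chloro in place of hydrogen on an aromatic carbon. The measured steps that bear on this position are those on the same amide-type nitrogen: the replacement of a hydrogen by the phenyl-bearing group left the number unchanged, and the exchange of allyl for phenyl raised it by a large amount. Neither step tests a chloro on the phenyl itself, and the change from phenyl to 4-chlorophenyl is smaller than either of those. Compound 3 already sits near the top of the range of this read-out, so the expected step in this assay is none beyond the scatter, with more room downward than upward. Compound 4 is therefore estimated at 90%, between 70% and 98%, meaning an expected step of a number 5 percentage points lower from compound 3 to compound 4 (within the scatter).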

Compound 4, a percentage reported as activity, at one concentration (the size of the read-out at that concentration, not a potency): 100%
The estimate for compound 4 lay 10 percentage points below the measured number; measured number above the stated range.
By their numbers in this assay, from the lowest: compound 2; then compounds 1, 3 and 4 (each within the scatter of the next).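

In this assay, the chloro, on an aromatic carbon para to a large group, is the first change shown on the phenyl ring itself, and it gives a number 5 percentage points higher from compound 3 to compound 4 (within the scatter), so the read-out at this concentration does not separate 4-chlorophenyl from phenyl. The large gap to the allyl compound also holds for the substituted ring, with a number 60 percentage points higher from compound 2 to compound 4 (beyond the scatter), while the comparison with the free amine gives a number 5 percentage points higher from compound 1 to compound 4 (within the scatter), so this chlorinated group on the amide-type nitrogen, like phenyl, stays level with the free amine. No evidence at hand bears on this result.

The number for compound 4 lies close to the top of the read-out at a single concentration, so the compounds shown leave open whether the chloro would make any difference at lower concentrations, where a smaller effect could be read. They also leave open how a methoxy group or a carboxylic acid at the same ring carbon would behave, and whether a benzyl group or a longer chain on the nitrogen would fall nearer the allyl or the phenyl compound.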